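Lactone to oxane swap on the thioether side chain

The source may report more compounds than this note shows. Statements on the series, on what has been measured and on what is new or still open speak of the compounds shown alone.

Values in an assay on microsomes from liver for inhibition of sterol O-acyltransferase 1 (Rattus norvegicus) (a higher number here means a weaker inhibitor, a lower number a stronger inhibitor), for the measured members of the series:
- compound 1 `C[C@]1(O)CC(=O)OC(CSc2nc(-c3ccccc3)c(-c3ccccc3)[nH]2)C1`: 140 nM
- compound 2 `CC1=CC(=O)OC(CSc2nc(-c3ccccc3)c(-c3ccccc3)[nH]2)C1`: 200 nM
- compound 3 `O=C1CCC(CSc2nc(-c3ccccc3)c(-c3ccccc3)[nH]2)N1`: 360 nM

Compound 3 carries the highest number of the three in this assay; its nearest neighbour is compound 2, reached by a 1.8-fold higher number from compound 2 to compound 3 (0.26 log units; within the scatter), while the step of a 2.6-fold higher number from compound 1 to compound 3 (0.41 log units; beyond the scatter) is modest but beyond the scatter.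

Compound 4 `c1ccc(-c2nc(SCC3CCCCO3)[nH]c2-c2ccccc2)cc1` differs from compound 3 by oxan-2-yl in place of 5-oxopyrrolidin-2-yl on a saturated chain carbon bound to a sulfur. All three measured steps concern a change of the ring group at this same place, and all were small: a 1.4-fold higher number from compound 1 to compound 2 (0.15 log units; within the scatter), a 2.6-fold higher number from compound 1 to compound 3 (0.41 log units; beyond the scatter) and a 1.8-fold higher number from compound 2 to compound 3 (0.26 log units; within the scatter). The two six-membered rings of compounds 1 and 2 sit at lower numbers than the five-membered ring of compound 3, but the spread across the three is narrow. On that basis the step to compound 4 is expected to be small, most likely towards a somewhat lower number or none beyond the scatter, and the expected step is a 1.4-fold lower number from compound 3 to compound 4 (0.16 log units; within the scatter).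

Compound 4 is therefore estimated at 250 nM in this assay, within a range of 100 nM to 600 nM.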

Compound 4, half-maximal inhibitory concentration: 210 nM
Compound 4: the middle estimate sits 1.2-fold (0.08 log units) above what was measured; low and high end bracket the measured number.
By their numbers in this assay, from the lowest: compounds 1, 2, 4 and 3 (each within the scatter of the next, the first and the last beyond it).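

In this assay, the step with oxan-2-yl in place of 5-oxopyrrolidin-2-yl is a 1.7-fold lower number from compound 3 to compound 4 (0.23 log units; within the scatter) and so gives no readable change, which shows that on this saturated chain carbon bound to a sulfur a ring with no hydrogen-bond donor and no double bond stands level with the one that has both. The smaller oxan-2-yl group also stays level with the two more heavily substituted six-membered rings, with a 1.1-fold higher number from compound 2 to compound 4 (0.02 log units; within the scatter) and a 1.5-fold higher number from compound 1 to compound 4 (0.18 log units; within the scatter) as its steps, so neither the extra atoms of compounds 1 and 2 nor the hydroxyl of compound 1 is needed to hold the value in this range. Within the data shown here, compound 4 thus bridges the series, and the only step beyond the scatter remains the one between compound 1 and compound 3, while no measurement available here explains this flat response.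

The compounds shown all carry a neutral ring at this place, so the effect of a basic piperidine amine or a carboxylic acid remains open. Equally open, going by these compounds, are an open-chain ether or a longer chain between the sulfur and the ring, and whether the two ring enantiomers differ.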